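Working notes: cytotoxicity across a small set of analogues

The source may report more compounds than this note shows. Statements on the series, on what has been measured and on what is new or still open speak of the compounds shown alone.

Measured so far:
Compound 1 `Cc1ccc(-c2nn(-c3ccccc3)cc2-c2nc3ccccc3n2C(=O)c2ccccc2)cc1` gives 204000 nM in an ADME assay on HEK-293T cells (Homo sapiens) for cytotoxicity, read by MTT assay, with a stated time of 24 h; on this read-out higher numbers stand for lower toxicity in this test and lower numbers for higher toxicity in this test.
Compound 2 `Cc1ccc(-c2nn(-c3ccccc3)cc2-c2nc3ccccc3n2C(=O)c2cccnc2)cc1` gives 189000 nM in this assay.
Compound 3 `O=C(c1ccccc1)n1c(-c2cn(-c3ccccc3)nc2-c2ccc(C(F)(F)F)cc2)nc2ccccc21` gives 168000 nM in this assay.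

The change pyridin-3-yl in place of phenyl on a carbonyl carbon gave a 1.1-fold lower number from compound 1 to compound 2 (0.03 log units; within the scatter). The cores of compound 1 and compound 3 differ by trifluoromethyl in place of methyl on an aromatic carbon, and that difference gave a 1.2-fold lower number from compound 1 to compound 3 (0.08 log units; within the scatter). All three numbers sit within the scatter of one another, so no order among them is claimed.

Compound 4 `O=C(c1cccnc1)n1c(-c2cn(-c3ccccc3)nc2-c2ccc(C(F)(F)F)cc2)nc2ccccc21` is not yet measured. It differs from compound 3 by pyridin-3-yl in place of phenyl on a carbonyl carbon, the same change as from compound 1 to compound 2, made at the same place. The step from compound 3 to compound 4 is therefore expected to be about a 1.1-fold lower number from compound 3 to compound 4 (0.03 log units; within the scatter), resting on the step of a 1.1-fold lower number from compound 1 to compound 2 (0.03 log units; within the scatter), which stayed within the scatter. Compound 4 is accordingly estimated at 155000 nM in this assay, with a range from 80000 nM to 300000 nM.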

Compound 4, half-maximal cytotoxic concentration: 158000 nM
For compound 4 the middle estimate is 1.0-fold (0.01 log units) below the measured one; the range from low to high includes it.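

In this assay, the change to pyridin-3-yl on the carbonyl carbon gave a 1.1-fold lower number from compound 3 to compound 4 (0.03 log units; within the scatter), in agreement with its earlier step: the same change on two cores in this assay, a 1.1-fold lower number (0.03 log units; within the scatter) from compound 1 to compound 2 and a 1.1-fold lower number (0.03 log units; within the scatter) from compound 3 to compound 4, 1.0-fold (0.01 log units) apart, within the scatter of two such steps. The change to trifluoromethyl gave a 1.2-fold lower number from compound 2 to compound 4 (0.08 log units; within the scatter), also in agreement with its earlier step: the same change on two cores in this assay, a 1.2-fold lower number (0.08 log units; within the scatter) from compound 1 to compound 3 and a 1.2-fold lower number (0.08 log units; within the scatter) from compound 2 to compound 4, 1.0-fold (0.01 log units) apart, within the scatter of two such steps. Each change thus read alike on the two cores that carry it, but all these steps lie within the scatter, so this shows neither a real effect of either change nor an order among the four compounds, and two cores set no rule for the wider series.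

Still open, going by these compounds, is how an amine or a carboxylic acid in place of the methyl or trifluoromethyl would read in this assay.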